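Benzhydryl-to-benzyl ester on the penam exocyclic acrylate

This account rests on a few compounds, and the source may have more. Where it says the series, first, only, none or still open, it means among the compounds named here.

Measured so far:
- compound 1 `CC1(C)[C@H](C(=O)OC(c2ccccc2)c2ccccc2)N2C(=O)/C(=C/C(=O)c3ccccc3)[C@H]2S1(=O)=O`, 19500 nM
- compound 2 `CC1(C)S[C@@H]2/C(=C\C(=O)OC(c3ccccc3)c3ccccc3)C(=O)N2[C@H]1C(=O)OC(c1ccccc1)c1ccccc1`, 15200 nM

In a functional assay on HT-1080 cells (Homo sapiens) for cytotoxicity, read by MTT assay, with a stated time of 48 h (on this read-out lower numbers stand for stronger inhibition and higher numbers for weaker inhibition), compound 1 gives 19500 nM and compound 2 gives 15200 nM; compound 2 holds the lower of the two numbers, but the gap to compound 1 sits within the usual scatter, so neither stands apart. Compound 3 `CC1(C)S[C@@H]2/C(=C\C(=O)OCc3ccccc3)C(=O)N2[C@H]1C(=O)OC(c1ccccc1)c1ccccc1` is not yet measured. It differs from compound 2 by hydrogen in place of phenyl on a saturated chain carbon bound to an aromatic carbon and an oxygen next to a carbonyl group. Among the compounds with values here, no step between measured compounds covers this change, so the expectation rests on the shared weak range of compound 1 and compound 2. The step from compound 2 to compound 3 is expected to be small, a 1.2-fold higher number from compound 2 to compound 3 (0.07 log units; within the scatter), in no fixed direction beyond the scatter. Compound 3 is estimated at 18000 nM, with a range from 7000 nM to 45000 nM.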

Compound 3, half-maximal inhibitory concentration: 11700 nM
For compound 3 the middle estimate is 1.5-fold (0.19 log units) above the measured one; measured number inside the range.
By their numbers in this assay, from the lowest: compounds 3, 2 and 1 (each within the scatter of the next).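

In this assay, hydrogen in place of phenyl on a saturated chain carbon bound to an aromatic carbon and an oxygen next to a carbonyl group gives a 1.3-fold lower number from compound 2 to compound 3 (0.11 log units; within the scatter) as its step. Losing one of the two phenyl groups at this position therefore leaves the number in the same weak range, so that phenyl is not needed to hold it there. Nothing available explains this result. Still open, as far as these compounds go, is whether an amine, a carboxylic acid or a longer chain on this carbon would move the number beyond the scatter.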